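The compounds below may be only part of what the source reports. "The series", "measured", "known", "first", "only" and "open" are said of these compounds alone.

Compound 2 (`CCC1(OC(=O)N2CCC(Oc3ncnc(Oc4ccc(S(C)(=O)=O)nc4C)c3F)CC2)CC1`): 333 nM
Compound 1 (`Cc1nc(S(C)(=O)=O)ccc1Oc1ncnc(OC2CCN(C(=O)OC(C)(C)C#N)CC2)c1F`): 1320 nM

The two measured compounds share one core and differ only in the group carried on the carbonyl carbon attached to the ring nitrogen. In a functional assay on isolated protein for inhibition of Glucose-dependent insulinotropic receptor (Rattus norvegicus), read by HTRF and cAMP accumulation (a higher number here means that more compound is needed for the effect, a lower number that less compound is needed), compound 2 gives 333 nM, while compound 1 gives 1320 nM. Within the data shown here, compound 2 thus holds the lower of the two numbers, and the single measured step is a 4.0-fold lower number from compound 1 to compound 2 (0.60 log units; beyond the scatter).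

Compound 3 (`Cc1nc(S(C)(=O)=O)ccc1Oc1ncnc(OC2CCN(C(=O)SC(C)(C)C)CC2)c1F`) is not yet measured. It differs from compound 2 as follows: a group of 5 heavy atoms (4 carbon, 1 sulfur; no ring) in place of a group of 6 heavy atoms (5 carbon, 1 oxygen; one three-membered non-aromatic ring of carbon only), on a carbonyl carbon. Among the measured compounds shown here, no measured step covers the exchange of oxygen for sulfur at this carbonyl carbon; the one step that exists concerns a different exchange at the same place, so it gives only a rough idea of how far the number can move when this group is changed. Because a 4.0-fold lower number from compound 1 to compound 2 (0.60 log units; beyond the scatter) shows a modest shift at this place, a shift of comparable size is plausible here, and for compound 3 the number is expected to come out somewhat higher than before, a 1.8-fold higher number from compound 2 to compound 3 (0.26 log units; within the scatter). Compound 3 is estimated at 600 nM, with a range from 200 nM to 2000 nM.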

Compound 3, half-maximal effective concentration: 30.7 nM
For compound 3 the middle estimate is 20-fold (1.29 log units) above the measured one, outside the stated range (below it).
By their numbers in this assay, from the lowest: compound 3; then compound 2; then compound 1.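

In this assay, the place on the carbonyl carbon proves far more responsive than the earlier pair suggested: (tert-butyl)sulfanyl, which links through sulfur rather than oxygen, gives an 11-fold lower number from compound 2 to compound 3 (1.04 log units; beyond the scatter), a large step beside the modest 4.0-fold lower number from compound 1 to compound 2 (0.60 log units; beyond the scatter). Set against 1-cyano-1-methylethoxy, the same group gives a 43-fold lower number from compound 1 to compound 3 (1.63 log units; beyond the scatter), so compound 3 has the lowest number of the three, with both of its steps beyond the scatter. This place can therefore move the number much further than the first step alone indicated, and a group attached through sulfur gives the lowest number among these three compounds.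

As far as these compounds go, the exchange from compound 2 changes both the atom on the carbonyl carbon and the carbon group behind it, so the share of each stays open; a tert-butoxy group or a 1-ethylcyclopropylsulfanyl group at this place would separate the two, and an amine there is also an open case. Nothing at hand bears on why the number falls so far at this place.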